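Notes on compound 3: (4-bromophenyl)sulfonyl at the amine nitrogen

A few compounds are considered here, and "the series" means these few. Any claim that something is new, unique, unknown or untested is made for them only; others in the source may bear on it.

Two compounds of the shared core have numbers in a functional assay on Ehrlich cells (Mus musculus) for cytotoxicity, read by trypan blue exclusion, with a stated time of 2 h, tested at 50 ug/mL; a lower number here means a weaker effect, a higher number a stronger effect of the compound at the concentration tested. Compound 1 `C=CCNC(=S)NC1=C(C#N)C(c2ccc(Cl)cc2Cl)C2=C(CCCC2=O)N1c1ccc(S(N)(=O)=O)cc1` gives 33%. Compound 2 `N#CC1=C(NC(=O)CCC(=O)O)N(c2ccc(S(N)(=O)=O)cc2)C2=C(C(=O)CCC2)C1c1ccc(Cl)cc1Cl` gives 50%, the higher of the two numbers and the starting point of the step considered here. For the measured compounds named here, the only measured step is a number 17 percentage points higher from compound 1 to compound 2 (beyond the scatter), a change carried out on the same amine nitrogen that compound 3 alters.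

Compound 3 `N#CC1=C(NS(=O)(=O)c2ccc(Br)cc2)N(c2ccc(S(N)(=O)=O)cc2)C2=C(C(=O)CCC2)C1c1ccc(Cl)cc1Cl` is not yet measured in this assay. It differs from compound 2 by (4-bromophenyl)sulfonyl in place of (2-carboxyethyl)carbonyl on an amine nitrogen. Going by the values given here, the measured step bears on this only loosely: it shows that a change at this nitrogen can move the read-out by a modest amount, but the entering group has no counterpart among the measured pairs, and compound 1 and compound 2 alone give no ground for a direction. The expected step of a number 8 percentage points lower from compound 2 to compound 3 (within the scatter) is therefore set as a small decrease that stays within the usual scatter, with a wide range to either side. Compound 3 is estimated at 42%, with a range from 20% to 65%.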

Compound 3, a percentage reported as activity, at one concentration (the size of the read-out at that concentration, not a potency): 90%
Beside the measured number, compound 3's estimate is 48 percentage points below it, outside the stated range (above it).
By their numbers in this assay, from the lowest: compound 1; then compound 2; then compound 3.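

At the amine nitrogen whose other neighbour is the double-bonded ring carbon, the read-out in this assay spans far more than the first pair suggested: (4-bromophenyl)sulfonyl in place of (2-carboxyethyl)carbonyl gives a large rise (a number 40 percentage points higher from compound 2 to compound 3 (beyond the scatter)), and the same group in place of the allyl thiourea side chain of compound 1 gives a larger one (a number 57 percentage points higher from compound 1 to compound 3 (beyond the scatter)). Compound 3 now stands highest of the three, with both of its steps beyond the scatter, and it alone carries a sulfonyl group on this nitrogen and an aromatic ring in the group there, so this position tolerates a larger, ring-bearing group without loss of the read-out. No measurement on hand accounts for the rise.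

The change swaps several features at once, so the sulfonyl link, the aromatic ring and the bromine cannot be separated on these three compounds. A plain phenylsulfonyl, a methylsulfonyl or a benzoyl group on the same nitrogen would divide these contributions, and a read-out at one concentration still leaves the potency of compound 3 open.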